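Swapping Fluoro for Hydroxy on the Pendant Aryl Ring

A few compounds are considered here, and "the series" means these few. Any claim that something is new, unique, unknown or untested is made for them only; others in the source may bear on it.

Compound 1, `COc1ccc(S(=O)(=O)N2CCc3cccc(-c4ccc([N+](=O)[O-])cc4)c32)cc1`, gives 51.3 nM in a functional assay on KB-VIN10 cells (Homo sapiens) for inhibition, with a stated time of 72 h; a higher number here means a weaker inhibitor, a lower number a stronger inhibitor.
Compound 2, `COc1ccc(S(=O)(=O)N2CCc3cccc(-c4cccnc4)c32)cc1`, gives 84.5 nM in this assay.
Compound 3, `COc1ccc(S(=O)(=O)N2CCc3cccc(-c4ccc(F)cc4)c32)cc1`, gives 94.6 nM in this assay.

Compound 3 has the highest of the three numbers, yet its gaps to the others, a 1.1-fold higher number from compound 2 to compound 3 (0.05 log units; within the scatter) and a 1.8-fold higher number from compound 1 to compound 3 (0.27 log units; within the scatter), are both within the scatter, so none of the three can be called more or less potent than another. All three share one core and differ only in the group attached to its aromatic carbon.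

Compound 4, `COc1ccc(S(=O)(=O)N2CCc3cccc(-c4ccc(O)cc4)c32)cc1`, differs from compound 3 by hydroxy in place of fluoro on an aromatic carbon. For the measured compounds named here, no measured pair involves a hydroxy group, so nothing speaks to this change directly. The nearest guidance comes from the three swaps already made at the same position: a 1.6-fold higher number from compound 1 to compound 2 (0.22 log units; within the scatter), a 1.8-fold higher number from compound 1 to compound 3 (0.27 log units; within the scatter) and a 1.1-fold higher number from compound 2 to compound 3 (0.05 log units; within the scatter), every one within the scatter, even though those groups are quite different from each other. The step to compound 4 is therefore expected to be a 1.1-fold higher number from compound 3 to compound 4 (0.02 log units; within the scatter), with no direction beyond the scatter. Compound 4 is estimated at 100 nM, with a range from 40 nM to 300 nM.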

Compound 4, half-maximal inhibitory concentration: 123 nM
Estimate against measurement, compound 4: 1.2-fold (0.09 log units) below; the measured number falls inside the stated range.
By their numbers in this assay, from the lowest: compounds 1, 2, 3 and 4 (each within the scatter of the next, the first and the last beyond it).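

Measured in this assay the hydroxy group, which brings a hydrogen-bond donor and a hydrogen-bond acceptor where fluoro brought neither, does not separate from fluoro (a 1.3-fold higher number from compound 3 to compound 4 (0.11 log units; within the scatter)) or from the pyridin-3-yl compound (a 1.5-fold higher number from compound 2 to compound 4 (0.16 log units; within the scatter)). For the compounds shown here, the new result does give the first step at this position that clears the scatter, a modest one (a 2.4-fold higher number from compound 1 to compound 4 (0.38 log units; beyond the scatter)), whereas every swap among nitro, fluoro and pyridin-3-yl stayed within it. This gap rests on a single pair, and compound 2 and compound 3 lie within the scatter of both compound 1 and compound 4, so the four form a shallow spread and not separate levels, and nothing measured here accounts for the gap.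

A methoxy group in place of the hydroxy would show whether the hydrogen on that oxygen has any bearing on the number, and an amine or a carboxylic acid at the same place would test how far the spread extends. The compounds shown also leave open whether the same swap behaves alike on a differently substituted sulfonyl aryl ring, as all four carry the same one.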